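The source may hold more compounds than are shown below. What is called first, only, known or untested is meant among the compounds shown, and "the series" means these compounds.

Measured so far:
- compound 1, `C/C(=N/N=C1\SCC(=O)N1Cc1ccc(F)cc1)c1cccs1`: 21500000 nM
- compound 2, `CC(C)=N/N=C1\SCC(=O)N1Cc1cccc([N+](=O)[O-])c1`: 19400000 nM

Both numbers come from a physicochemical assay, with a stated time of 30 min; a higher number here means a weaker inhibitor, a lower number a stronger inhibitor. Compound 1 stands at the highest of the two numbers, and compound 2 lies close to it; the two values sit within the scatter of each other, so no order between them can be read. Within the data shown here, no step between two measured compounds that differ in one place is available in this set, so nothing shows how a single change moves this assay.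

Compound 3, `C/C(=N/N=C1\SCC(=O)N1Cc1ccc(F)cc1)c1ccccn1`, is not yet measured. It differs from compound 1 as pyridin-2-yl in place of thiophen-2-yl on a carbon with a double bond to nitrogen. The group that leaves is thiophen-2-yl; the group that enters is pyridin-2-yl. Nothing measured here bears on such a change, and the two measured values lie at the weak end of the scale. The expected step is a 1.1-fold lower number from compound 1 to compound 3 (0.03 log units; within the scatter), none beyond the scatter in either direction. Compound 3 is estimated at 20000000 nM in this assay, with a range from 8000000 nM to 50000000 nM.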

Compound 3, half-maximal inhibitory concentration: 16200000 nM
For compound 3 the middle estimate is 1.2-fold (0.09 log units) above the measured one; the measured number falls inside the stated range.
By their numbers in this assay, from the lowest: compounds 3, 2 and 1 (each within the scatter of the next).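

In this assay, pyridin-2-yl in place of thiophen-2-yl gives a 1.3-fold lower number from compound 1 to compound 3 (0.12 log units; within the scatter) and so cannot be told apart from no change. On a carbon with a double bond to nitrogen, one six-membered aromatic ring with 1 hetero atom thus reads the same as one five-membered aromatic ring with 1 hetero atom, and the number stays at the weak end of the scale. No measurement in hand speaks to why these two rings read alike.

On these data alone, what a cyclohexyl ring at this carbon, or an amine or a carboxylic acid carried on the aromatic ring there, would do to the number remains open. As far as these compounds go, whether any single change can move the number beyond the scatter also remains open.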